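Ester for ketone on a shared bicyclic scaffold

The compounds below may be only part of what the source reports. "The series", "measured", "known", "first", "only" and "open" are said of these compounds alone.

The measured compounds:
Compound 1 `CO[C@H]1C(=O)N2C(C(=O)C(C)(C)C)=C(CSc3ccccn3)CS(=O)(=O)C12`: 28 h
Compound 2 `CO[C@H]1C(=O)N2C(C(=O)C(C)(C)C)=C(C)[C@@H](Sc3ccccn3)S(=O)(=O)C12`: 24 h
Compound 3 `CO[C@H]1C(=O)N2C(C(=O)OC(C)(C)C)=C(C)[C@@H](Sc3ccccn3)S(=O)(=O)C12`: 4.1 h

In a physicochemical assay, at pH 7.4 (on this read-out higher numbers stand for a longer-lived compound and lower numbers for a shorter-lived compound), compound 1 gives 28 h, and compound 2 gives 24 h; these two values lie within the scatter of one another. Compound 3 gives 4.1 h. The step from compound 2 to compound 3 is a single change, (tert-butoxy in place of tert-butyl on a carbonyl carbon), and it produced a 5.9-fold lower number from compound 2 to compound 3 (0.77 log units; beyond the scatter).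

Compound 4 `CO[C@H]1C(=O)N2C(C(=O)OC(C)(C)C)=C(CSc3ccccn3)CS(=O)(=O)C12` has not yet been measured. It stands to compound 1 as compound 3 stands to compound 2: the change tert-butoxy in place of tert-butyl on a carbonyl carbon is the same change, made at a place described in the same words. How the core of compound 1 differs from the core of compound 2 is not broken down here.

Compound 4 is therefore expected to fall by about the same amount, a 6.0-fold lower number from compound 1 to compound 4 (0.78 log units; beyond the scatter), because compound 2 to compound 3 gave a 5.9-fold lower number from compound 2 to compound 3 (0.77 log units; beyond the scatter). The estimate for compound 4 in this assay is 4.7 h, with a likely range from 2.5 h to 9 h.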

Compound 4, half-life: 5.1 h
Estimate against measurement, compound 4: 1.1-fold (0.04 log units) below, within the range that was stated.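

In this assay, tert-butoxy in place of tert-butyl on a carbonyl carbon gave a 5.5-fold lower number from compound 1 to compound 4 (0.74 log units; beyond the scatter), which matches in direction and closely in size a 5.9-fold lower number from compound 2 to compound 3 (0.77 log units; beyond the scatter) seen on the core of compound 2. The change therefore carried from one core to the other in the one case that can be read here, and the lower number appeared on both. These are only two matched pairs, however, so they do not establish a rule for the series or for other cores, and no measurement shown here bears on why the number falls with this change.

The compounds shown leave open whether the same fall would follow with other groups on that carbonyl carbon, such as methoxy, an amine or a hydroxyl group that would make a carboxylic acid. They also leave open whether a longer chain in place of tert-butyl would keep the number of the ketone pair on either core.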